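Compound 1 to compound 4: hydrogen for fluoro

The compounds below may be only part of what the source reports. "The series", "measured", "known", "first", "only" and "open" are said of these compounds alone.

In a functional assay on MES-SA/Dx5 cells (Homo sapiens) for antiproliferative activity, with a stated time of 72 h (a higher number here means a weaker inhibitor, a lower number a stronger inhibitor), compound 1 (`COc1cc(/C=C\c2cc3cc(F)ccc3s2)cc(OC)c1OC`) stands at "not determined" (no result reported), so it has no single number and no rank in the series. Compound 2 (`COc1ccsc1/C=C\c1cc(OC)c(OC)c(OC)c1`) shares that status, with compound 2 at "not determined" (no result reported). For the measured compounds named here, the only number comes from compound 3 (`COc1csc(/C=C\c2cc(OC)c(OC)c(OC)c2)c1`), and in this assay compound 3 gives 27 nM.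

Compound 4 (`COc1cc(/C=C\c2cc3ccccc3s2)cc(OC)c1OC`) is the unmeasured partner of compound 1. The structural change is hydrogen in place of fluoro on an aromatic carbon. Going by the values given here, the series holds no measured step to calibrate this exchange, and the missing result for compound 1 leaves no starting value. On that thin basis, no step beyond the usual scatter is expected in this assay, and no direction is favoured. Among the compounds with values here, the estimate therefore leans on the single number available, the value of compound 3 at 27 nM, and its range is kept wide. Compound 4 is expected at about 30 nM, with an estimated range of 7 nM to 150 nM.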

Compound 4, half-maximal inhibitory concentration: 19 nM
Compound 4: middle estimate off by 1.6-fold (0.20 log units), on the high side, within the range that was stated.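

In this assay compound 1 stands at "not determined" (no result reported) and compound 4 at 19 nM, so no step can be read between compound 1 and compound 4. The compounds shown leave open what hydrogen in place of fluoro does in this assay. No supporting data bear on this result.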